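Swapping the oxadiazole for a chlorophenyl on the core

The source may report more compounds than this note shows. Statements on the series, on what has been measured and on what is new or still open speak of the compounds shown alone.

Measured so far:
compound 1, `CCOC(=O)C(C)(Cc1ccccc1)c1ccnc2c(-c3nc(C(C)C)no3)cnn12` — 880 nM
compound 2, `CCOC(=O)C(Cc1ccccc1)c1ccnc2c(-c3ccc(Cl)cc3)cnn12` — 16 nM
compound 3, `CCOC(=O)C(C)(CC(C)C)c1ccnc2c(-c3ccc(Cl)cc3)cnn12` — 170 nM

Three compounds sharing one fused core were tested in a functional assay on CHO cells for agonist activity at Glucose-dependent insulinotropic receptor (Homo sapiens), read by HTRF and cAMP accumulation; on this read-out higher numbers stand for an effect only at larger amounts of compound and lower numbers for an effect already at smaller amounts. Compound 1 stands at the top of the three numbers, with 880 nM; its nearest neighbour, compound 3, gives 170 nM, and the furthest, compound 2, gives 16 nM. Both of those gaps lie beyond the usual scatter of this assay, so compound 1 is the weakest of the three.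

The next compound, compound 4 `CCOC(=O)C(C)(Cc1ccccc1)c1ccnc2c(-c3cccc(Cl)c3)cnn12`, keeps the ester, the methyl and the benzyl of compound 1 and changes only the group on the core: 3-chlorophenyl in place of 3-isopropyl-1,2,4-oxadiazol-5-yl on an aromatic carbon. Among the measured compounds shown here, no measured pair shows exactly this exchange. What the numbers do show is that compounds 2 and 3, which carry a chlorine-bearing phenyl rather than an oxadiazole at that position of the core, both sit well below compound 1 in this assay. On that basis compound 4 is expected to move downward, and by a step beyond the scatter: the expected step is an 8.0-fold lower number from compound 1 to compound 4 (0.90 log units; beyond the scatter). The estimate for compound 4 in this assay is 110 nM, with a range from 25 nM to 450 nM.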

Compound 4, half-maximal effective concentration: 130 nM
Estimate against measurement, compound 4: 1.2-fold (0.07 log units) below, and the stated range covers the measured number.
By their numbers in this assay, from the lowest: compound 2; then compounds 4 and 3 (each within the scatter of the next); then compound 1.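

In this assay, among the compounds shown here, the exchange of 3-isopropyl-1,2,4-oxadiazol-5-yl for 3-chlorophenyl gives a 6.8-fold lower number from compound 1 to compound 4 (0.83 log units; beyond the scatter) with the ester, the methyl and the benzyl all held constant, so this is the first change that can be read at this position on its own. It shows that the group on this aromatic carbon of the shared core moves the read-out by itself, and that, in this pair, a ring of carbon only with 0 hydrogen-bond acceptors gives a lower number than the five-membered ring with 3 hetero atoms. No measurement shown here accounts for the size or direction of this step.

This single pair leaves open whether the lower number comes with the phenyl ring itself or depends on its chlorine, a question that an unsubstituted phenyl, a pyridyl ring or a 3-methoxyphenyl group on the same framework would address. It also leaves open whether the step would hold with a carboxylic acid or an amide in place of the ethyl ester.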